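The source may report more compounds than this note shows. Statements on the series, on what has been measured and on what is new or still open speak of the compounds shown alone.

Measured compounds:
Compound 1 `Nc1nc(Cl)c2ncn(Cc3ccc(CCl)cc3)c2n1`: 47900 nM
Compound 2 `ClCc1cccc(Cn2cnc3c(Cl)nc(Cl)nc32)c1`: 3460 nM
Compound 3 `ClCc1ccc(Cn2cnc3c(Cl)nc(Cl)nc32)cc1`: 33100 nM

The three compounds were tested in a functional assay on UACC-257 cells (Homo sapiens) for cytotoxicity, read by sulforhodamine B assay, with a stated time of 48 h; a higher number here means a weaker inhibitor of growth, a lower number a stronger inhibitor of growth. Compound 2 gives the lowest number, and its steps to the other two are beyond the scatter, so it is the strongest inhibitor of growth among them. Compound 2 and compound 3 are built from the same atoms joined differently; the difference between their cores is not broken down here, and only the two values show how they compare. Compound 3 and compound 1 differ in one place, (amino in place of chloro on an aromatic carbon), and this change made a step of a 1.4-fold higher number from compound 3 to compound 1 (0.16 log units; within the scatter).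

Compound 4 `Nc1nc(Cl)c2ncn(Cc3cccc(CCl)c3)c2n1` has not yet been measured. It stands to compound 2 as compound 1 stands to compound 3: the change is amino in place of chloro on an aromatic carbon, the same change at the same place. Because the step of a 1.4-fold higher number from compound 3 to compound 1 (0.16 log units; within the scatter) stayed within the scatter, the step from compound 2 to compound 4 in this assay is expected to be small as well, a 1.3-fold higher number from compound 2 to compound 4 (0.11 log units; within the scatter). Compound 4 is therefore estimated at 4500 nM, with a likely range from 1800 nM to 11000 nM.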

Compound 4, concentration for total growth inhibition: 19500 nM
Beside the measured number, compound 4's estimate is 4.3-fold (0.64 log units) below it; measured number above the stated range.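

Amino in place of chloro on an aromatic carbon gave, in this assay, a 5.6-fold higher number from compound 2 to compound 4 (0.75 log units; beyond the scatter), so a change that stayed within the scatter on the core of compound 3 weakened growth inhibition on the core of compound 2. The change therefore does not carry a fixed size from one of these cores to the other: the same change on two cores in this assay, a 1.4-fold higher number (0.16 log units; within the scatter) from compound 3 to compound 1 and a 5.6-fold higher number (0.75 log units; beyond the scatter) from compound 2 to compound 4, 3.9-fold (0.59 log units) apart, beyond the scatter of two such steps. Among the compounds shown here, this comparison rests on only two steps, and it shows neither why the two cores respond differently nor how the same change would behave on any further core.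

The compounds shown carry only chloro or amino at this place, so what a methoxy group, a methylamino group or a hydroxyl group would do there remains open. All of them also keep the chloromethyl group, and whether a hydroxymethyl group or a longer chain in its stead would preserve the growth inhibition of compound 2 is likewise unanswered.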